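Hydrazone to aryl imine to arylhydrazone at the imine nitrogen

The source may report more compounds than this note shows. Statements on the series, on what has been measured and on what is new or still open speak of the compounds shown alone.

Compound 2 `O=C1Nc2ccc(S(=O)(=O)N3CCOCC3)cc2/C1=N/c1ccc(Cl)cc1` gives 11800 nM in a functional assay on HepG2 cells (Homo sapiens) for cytotoxicity, read by sulforhodamine B assay, with a stated time of 24 h (on this read-out lower numbers stand for stronger inhibition and higher numbers for weaker inhibition), the smallest number of the three shown; compound 3 `COc1ccc(-c2c(C#N)c(N)n(/N=C3\C(=O)Nc4ccc(S(=O)(=O)N5CCOCC5)cc43)c(=O)c2C#N)cc1` gives 15000 nM, within the scatter of it, while compound 1 `O=C1Nc2ccc(S(=O)(=O)N3CCOCC3)cc2/C1=N/NS(=O)(=O)c1ccccc1` gives 23900 nM, beyond it. Among the compounds with values here, the one step that bears on the next change is a 2.0-fold lower number from compound 1 to compound 2 (0.31 log units; beyond the scatter). Compound 4 `O=C1Nc2ccc(S(=O)(=O)N3CCOCC3)cc2/C1=N/Nc1ccccc1` carries anilino in place of 4-chlorophenyl on a double-bonded nitrogen, so it holds the attached nitrogen of compound 1 together with the carbon-only aromatic ring of compound 2, without the chlorine. Within the data shown here, with only one comparable step, the expectation is a modest rise back toward compound 1, expected as a 1.5-fold higher number from compound 2 to compound 4 (0.18 log units; within the scatter), that is a number near the middle of the three measured values. Compound 4 is therefore estimated at 18000 nM, with a range from 9000 nM to 40000 nM.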

Compound 4, half-maximal inhibitory concentration: 15600 nM
For compound 4 the middle estimate is 1.2-fold (0.06 log units) above the measured one, within the range that was stated.
By their numbers in this assay, from the lowest: compounds 2, 3, 4 and 1 (each within the scatter of the next, the first and the last beyond it).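

In this assay, anilino in place of 4-chlorophenyl on the double-bonded nitrogen gives a 1.3-fold higher number from compound 2 to compound 4 (0.12 log units; within the scatter), and phenyl in place of phenylsulfonyl on the amine nitrogen gives a 1.5-fold lower number from compound 1 to compound 4 (0.19 log units; within the scatter). Both steps lie within the scatter, so compound 4 cannot be separated from either neighbour, although compound 1 and compound 2 lie beyond the scatter of each other. The first step also swaps chlorine for nitrogen at once, so the two cannot be read apart. Open, as far as these compounds go, is whether 4-chloroanilino or a carboxylic acid on the anilino ring would move the number beyond the scatter of compound 4. No measurement shown gives a reason for these steps.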